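Methyl addition in the trifluoromethyl series: expected tolerance

The source may report more compounds than this note shows. Statements on the series, on what has been measured and on what is new or still open speak of the compounds shown alone.

In an ADME assay on Vero 76 cells (Chlorocebus sabaeus) for cytotoxicity, read by MTT assay, with a stated time of 96 h (a higher number here means that more compound is tolerated, a lower number that less compound is tolerated), compound 3 (`FC(F)(F)c1ccc(NCc2cn(-c3ccccc3)nc2-c2ccccc2)cc1`) gives the lower of the two numbers (17000 nM), and compound 1 (`Brc1ccc(NCc2cn(-c3ccccc3)nc2-c2ccccc2)cc1`) gives the higher (52000 nM). Compound 2 (`Cc1ccc(NCc2cn(-c3ccccc3)nc2-c2ccc(C)cc2)cc1`), which carries a 4-methylphenyl, reaches only a limit of the assay (> 100000 nM). Compound 4 (`Cc1ccc(-c2nn(-c3ccccc3)cc2CNc2ccc(C(F)(F)F)cc2)cc1`) differs from compound 3 by methyl in place of hydrogen on an aromatic carbon, para to a large group. Among the measured compounds shown here, the only measured step (a 3.1-fold lower number from compound 1 to compound 3 (0.49 log units; beyond the scatter)) is modest, swaps bromo for trifluoromethyl at another place, and gives no size for this change. The expected step stays within the scatter (a 1.3-fold higher number from compound 3 to compound 4 (0.11 log units; within the scatter)). Compound 4 is estimated at 22000 nM (expected range 9000 nM to 60000 nM).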

Compound 4, half-maximal cytotoxic concentration: 45000 nM
Beside the measured number, compound 4's estimate is 2.0-fold (0.31 log units) below it; low and high end bracket the measured number.
By their numbers in this assay, from the lowest: compound 3; then compounds 4 and 1 (each within the scatter of the next). At a limit, above all of these: compound 2.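

In this assay, among the compounds shown here, the earlier compounds gave no step at this position; phenyl to 4-methylphenyl now gives a 2.6-fold higher number from compound 3 to compound 4 (0.42 log units; beyond the scatter), so methyl here does change the number. With 4-methylphenyl kept, swapping the remaining methyl for trifluoromethyl gives an at least 2.2-fold lower number from compound 2 to compound 4 (0.34 log units; beyond the scatter). The value of compound 2 is a limit, not a number: the limit of > 100000 nM in this assay, at which 1 of the 4 values shown sits.

On these data alone, it remains open whether chloro, methoxy or a carboxylic acid in place of this methyl would move the number the same way. Also open, as far as these compounds go, is whether methyl gives a similar step with bromo in place of trifluoromethyl.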